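A Hydroxymethyl Added to Compound 2: What to Expect

The source may report more compounds than this note shows. Statements on the series, on what has been measured and on what is new or still open speak of the compounds shown alone.

Compound 1 `[N-]=[N+]=NC[C@H]1NC[C@@H](O)[C@H]1O` gives 127000 nM in an assay on isolated protein for inhibition of alpha-galactosidase (Coffea arabica), with stated times of 5 min and 20 min; a lower number here means a stronger inhibitor, a higher number a weaker inhibitor.
Compound 2 `O[C@@H]1[C@H](O)CN[C@@H]1Cn1cc(-c2ccccc2)nn1` gives 14000 nM in this assay.
Compound 3 `O[C@@H]1[C@H](O)CN[C@@H]1CCn1cc(-c2ccccc2)nn1` gives 107000 nM in this assay.

Of the three measured compounds, compound 2 has the lowest number in this assay, and its distance to both compound 3 and compound 1 lies beyond the usual scatter, so compound 2 counts as the strongest inhibitor of this small group. Compound 4 `OCc1ccc(-c2cn(C[C@H]3NC[C@@H](O)[C@H]3O)nn2)cc1` has not yet been measured. It differs from compound 2 in one place: hydroxymethyl in place of hydrogen on an aromatic carbon, para to a large group. Among the measured compounds shown here, no measured pair in this set shows what such an addition does, so there is no direct precedent to lean on. Compound 4 is therefore expected to land close to compound 2, with only a modest step, and the estimated step from compound 2 to compound 4 is a 1.4-fold lower number from compound 2 to compound 4 (0.15 log units; within the scatter). For compound 4 the expected value in this assay is 10000 nM, within a range from 3000 nM to 40000 nM.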

Compound 4, half-maximal inhibitory concentration: 14000 nM
For compound 4 the middle estimate is 1.4-fold (0.15 log units) below the measured one; the range from low to high includes it.
By their numbers in this assay, from the lowest: compounds 2 and 4 (each within the scatter of the next); then compounds 3 and 1 (each within the scatter of the next).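

In this assay, putting hydroxymethyl in place of hydrogen on an aromatic carbon, para to a large group, gives no change at the digits printed from compound 2 to compound 4 (within the scatter). Among the compounds shown here, this is the first pair in the set that differs in one place, and it shows that this position can carry a group of 2 heavy atoms, with 1 hydrogen-bond donor and 1 hydrogen-bond acceptor, without a change in inhibition that stands out from ordinary repeat variation. Nothing available explains why the number stays flat here.

One addition at one position cannot show whether this position is generally indifferent to what it carries, since an amine, a carboxylic acid or a longer chain could behave differently there. Going by these compounds, it also remains open whether hydroxymethyl would give the same outcome on another carbon of the aromatic ring.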